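Anilinoquinazoline ureas: a trifluoromethyl for a tert-butyl

This account rests on a few compounds, and the source may have more. Where it says the series, first, only, none or still open, it means among the compounds named here.

Compound 1 `O=C(Nc1cccc(Cl)c1)Nc1cccc(CNc2ncnc3ccccc23)c1`: > 50000 nM
Compound 2 `COc1cc2ncnc(NCc3cccc(NC(=O)Nc4ccc(C(C)(C)C)cc4)c3)c2cc1OC`: 6850 nM

In a functional assay on HepG2 cells (Homo sapiens) for antiproliferative activity, read by MTT assay (on this read-out lower numbers stand for stronger inhibition and higher numbers for weaker inhibition), compound 1 gives only a limit, > 50000 nM. Going by the values given here, compound 2 gives 6850 nM in this assay, the only number among the two values. The value of compound 1 is a limit (the limit of > 50000 nM in this assay, at which 1 of the 2 values shown sits). Compound 3 `COc1cc2ncnc(NCc3cccc(NC(=O)Nc4cccc(C(F)(F)F)c4)c3)c2cc1OC` differs from compound 2 by 3-(trifluoromethyl)phenyl in place of 4-(tert-butyl)phenyl on an amide-type nitrogen. Among the compounds with values here, no measured pair isolates this change, so the expected step from compound 2 to compound 3 is small, a 1.4-fold lower number from compound 2 to compound 3 (0.14 log units; within the scatter), within the usual scatter. Compound 3 is therefore expected to give 5000 nM, between 1500 nM and 20000 nM.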

Compound 3, half-maximal inhibitory concentration: 34200 nM
Beside the measured number, compound 3's estimate is 6.8-fold (0.84 log units) below it; the measured number lies above the stated range.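

Going by these compounds alone, this is the first measured change on this amide-type nitrogen, and it matters: in this assay, 3-(trifluoromethyl)phenyl in place of 4-(tert-butyl)phenyl brings a 5.0-fold higher number from compound 2 to compound 3 (0.70 log units; beyond the scatter) and so weaker inhibition. Nothing measured here explains why the number rises.

The two groups differ both in the substituent and in where it sits on the phenyl ring, so these two effects cannot be told apart from the compounds shown. On these data alone, it also remains open how a phenyl ring carrying an amine or a carboxylic acid would behave on this nitrogen.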